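Chloro to methyl on the same aromatic carbon

The compounds below may be only part of what the source reports. "The series", "measured", "known", "first", "only" and "open" are said of these compounds alone.

Measured in a functional assay on CHO cells for agonist activity at Free fatty acid receptor 1 (Homo sapiens), read by FLIPR and calcium flux (a lower number here means that less compound is needed, a higher number that more compound is needed for the effect), so far:
compound 1 `Cc1noc(C)c1-c1cccc(COc2ccc3c(c2)OCC3CC(=O)O)c1` — compound 1 gives 27.5 nM
compound 2 `Cc1noc(C)c1-c1ccc(Cl)c(COc2ccc3c(c2)OCC3CC(=O)O)c1` — compound 2 gives 39.7 nM
compound 3 `Cc1ccc(-c2c(C)noc2C)cc1COc1ccc2c(c1)OCC2CC(=O)O` — not yet measured

Among the measured compounds shown here, compound 2 holds the higher of the two numbers so far; the only other measured compound, compound 1, lies within the scatter of it. For the measured compounds named here, the single measured step, a 1.4-fold higher number from compound 1 to compound 2 (0.16 log units; within the scatter), put chloro in place of hydrogen on the aromatic carbon concerned and stayed within the scatter.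

Compound 3 differs from compound 2 by methyl in place of chloro on an aromatic carbon. The step of a 1.4-fold higher number from compound 1 to compound 2 (0.16 log units; within the scatter) bears on this exchange, as it altered the same aromatic carbon, and it was small. Compound 3 is therefore expected to remain close to compound 2 in this assay, with a 1.1-fold lower number from compound 2 to compound 3 (0.05 log units; within the scatter) and nothing beyond the scatter. For compound 3 the estimate is 35 nM, in a range from 15 nM to 85 nM.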

Compound 3, half-maximal effective concentration in the Free fatty acid receptor 1 assay: 53.7 nM
Compound 3: the middle estimate sits 1.5-fold (0.19 log units) below what was measured, within the range that was stated.
By their numbers in the Free fatty acid receptor 1 assay, from the lowest: compounds 1, 2 and 3 (each within the scatter of the next).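

In the Free fatty acid receptor 1 assay this aromatic carbon, ortho to a large group and para to a 3,5-dimethyl-1,2-oxazol-4-yl group, now has a second substituent to compare: compound 1 with hydrogen gives 27.5 nM, compound 2 with chloro gives 39.7 nM and compound 3 with methyl gives 53.7 nM; methyl against chloro gives a 1.4-fold higher number from compound 2 to compound 3 (0.13 log units; within the scatter) and methyl against hydrogen gives a 2.0-fold higher number from compound 1 to compound 3 (0.29 log units; within the scatter), so hydrogen, chloro and methyl all stay within the scatter of one another here. In a physicochemical assay for lipophilicity, read by HPLC, with a stated time of 24 h, at pH 7.4, tested at 100 uM (on this read-out lower numbers stand for lower lipophilicity and higher numbers for higher lipophilicity), compound 2 gives 2.13 and compound 3 gives 2.07, and the exchange of chloro for methyl gives a number 0.06 log units lower from compound 2 to compound 3 (within the scatter), so neither read-out separates these two groups. Nothing measured here accounts for this flat picture.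

The compounds shown leave open whether the same position keeps its numbers in the Free fatty acid receptor 1 read-out with a different kind of group, such as an amine, a carboxylic acid or a longer chain. They also leave open whether methyl and chloro would read alike on the other carbons of this ring.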